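The source may hold more compounds than are shown below. What is called first, only, known or untested is meant among the compounds shown, and "the series" means these compounds.

Compound 1 `COc1cc(-c2ccnc3cc(-c4ccc(C)cc4)nn23)cc(OC)c1OC` gives 48 nM in a functional assay on HCT-116 cells (Homo sapiens) for inhibition, read by CCK-8 assay, with a stated time of 48 h (on this read-out higher numbers stand for weaker inhibition and lower numbers for stronger inhibition), and compound 2 `COc1cc(-c2ccnc3cc(-c4ccc5c(ccn5C)c4)nn23)cc(OC)c1OC` gives 39 nM in this assay. Within the data shown here, the single measured step, a 1.2-fold lower number from compound 1 to compound 2 (0.09 log units; within the scatter), stays within the scatter; compound 2 holds the lowest of the two numbers, with compound 1 within the scatter of it. Compound 3 `C=Cc1ccc(-c2cc3nccc(-c4cc(OC)c(OC)c(OC)c4)n3n2)cc1` differs from compound 2 by 4-vinylphenyl in place of 1-methyl-1H-indol-5-yl on an aromatic carbon. Among the measured compounds shown here, only the step from compound 1 to compound 2 bears on this exchange on the same aromatic carbon, and it hardly moved the number; 4-vinylphenyl shares its six-membered aromatic ring of carbon only with 4-methylphenyl. The expected step is therefore a 1.2-fold higher number from compound 2 to compound 3 (0.07 log units; within the scatter), not beyond the scatter. Compound 3 is estimated at 46 nM, between 20 nM and 110 nM.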

Compound 3, half-maximal inhibitory concentration: 1060 nM
Estimate against measurement, compound 3: 23-fold (1.36 log units) below, outside the stated range (above it).
By their numbers in this assay, from the lowest: compounds 2 and 1 (each within the scatter of the next); then compound 3.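

A small change on the aryl group at this position carries a large cost: vinyl in place of methyl gives a 22-fold higher number from compound 1 to compound 3 (1.34 log units; beyond the scatter) in this assay and 4-vinylphenyl in place of 1-methyl-1H-indol-5-yl gives a 27-fold higher number from compound 2 to compound 3 (1.43 log units; beyond the scatter) on the same aromatic carbon. Tolerance here does not extend to every aryl group, and a six-membered aromatic ring of carbon only does not by itself preserve the number: compound 1 and compound 3 both carry one. Nothing available bears on the reason for this loss.

As far as these compounds go, whether the loss is confined to vinyl remains open. Ethyl, methoxy or an amine in place of that vinyl would show how narrow the tolerance is.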